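A few compounds are considered here, and "the series" means these few. Any claim that something is new, unique, unknown or untested is made for them only; others in the source may bear on it.

Working notes. In a functional assay on UACC-62 cells (Homo sapiens) for inhibition, read by sulforhodamine B assay, with a stated time of 48 h (a lower number here means a stronger inhibitor of growth, a higher number a weaker inhibitor of growth), compound 2 `COc1cc(-c2nn(-c3cccc(NC(=O)Nc4ccc(Cl)c(Cl)c4)c3)cc2-c2ccncc2)ccc1Cl` gives 773 nM, the lowest of the two numbers in hand. Its nearest neighbour is compound 1 `O=C(Nc1cccc(-n2cc(-c3ccncc3)c(-c3ccc(Cl)c(O)c3)n2)c1)Nc1cccc(C(F)(F)F)c1`, which in this assay gives 1650 nM; the two values stand apart beyond the scatter. Compound 1 differs from compound 2 in more than one place, so no single step can be read between them; they show only a hydroxy-bearing compound at the higher number and a methoxy-bearing one at the lower.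

Compound 3 `O=C(Nc1cccc(-n2cc(-c3ccncc3)c(-c3ccc(Cl)c(O)c3)n2)c1)Nc1ccc(Cl)c(Cl)c1` is compound 2 with the change (hydrogen in place of methyl on an oxygen on an aromatic ring), methoxy to hydroxy on the 4-chloro-3-methoxyphenyl. Going by the values given here, no measured pair shows this change alone. With compound 1 carrying the same hydroxy at 1650 nM while differing elsewhere too, only a modest move is expected in this assay, if any beyond the scatter, leaning weaker. The expected step is a 1.3-fold higher number from compound 2 to compound 3 (0.11 log units; within the scatter). For compound 3 the estimate is 1000 nM, with a range from 400 nM to 2500 nM.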

Compound 3, concentration for 50% growth inhibition: 1110 nM
Compound 3: middle estimate off by 1.1-fold (0.05 log units), on the low side; the range from low to high includes it.
By their numbers in this assay, from the lowest: compounds 2, 3 and 1 (each within the scatter of the next, the first and the last beyond it).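

In this assay, the change from methoxy to hydroxy on the 4-chloro-3-methoxyphenyl can now be read alone: a 1.4-fold higher number from compound 2 to compound 3 (0.16 log units; within the scatter), so the assay does not separate these two groups at this place. With the hydroxy held, 3,4-dichlorophenyl in place of 3-(trifluoromethyl)phenyl on an amide-type nitrogen gives a 1.5-fold lower number from compound 1 to compound 3 (0.17 log units; within the scatter), so these two groups are not separated either. No measurement offered here bears on the reason for either step.

Still open, as far as these compounds go, is how an amine or a carboxylic acid in place of the hydroxy on the 4-chloro-3-hydroxyphenyl would read in this assay. From the compounds shown here alone, a longer chain than methyl on that oxygen, such as ethyl or propyl, is equally open, as is whether the series holds its growth inhibition with such groups.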